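The source may hold more compounds than are shown below. What is called first, only, known or untested is meant among the compounds shown, and "the series" means these compounds.

Measured in a functional assay on A549 cells (Homo sapiens) for antiproliferative activity, read by MTT assay, with a stated time of 48 h; a lower number here means a stronger inhibitor, a higher number a weaker inhibitor:
- compound 1 `COc1ccc(/C=C/c2cc(OC)cc(OC)c2/C=C/C(=O)c2ccc(C)cc2)cc1` gives 3.6 ug/mL
- compound 2 `COc1ccc(/C=C/c2cc(OC)cc(OC)c2/C=C/C(=O)c2ccccc2C)cc1` gives 5.9 ug/mL

For the measured compounds named here, compound 2 lies within the scatter of compound 1, the only other measured compound. Compound 3 `COc1ccc(/C=C/c2cc(OC)cc(OC)c2/C=C/C(=O)c2ccccc2)cc1` differs from compound 2 by hydrogen in place of methyl on an aromatic carbon with hydrogen in place of methyl on an aromatic carbon. Going by the values given here, one measured step bears on this change: a 1.6-fold higher number from compound 1 to compound 2 (0.21 log units; within the scatter) with 2-methylphenyl in place of 4-methylphenyl on a carbonyl carbon. That step moves the methyl and removes none, so no measurement shows its loss directly. Given that small step for compound 2 a 1.6-fold higher number from compound 1 to compound 2 (0.21 log units; within the scatter) no shift beyond the scatter is expected in this assay and no direction is firmly expected. The estimate for compound 3 means a 1.3-fold lower number from compound 2 to compound 3 (0.12 log units; within the scatter) as the expected outcome. For compound 3 the estimated value is 4.5 ug/mL with an expected range of 2 ug/mL to 10 ug/mL around it.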

Compound 3, half-maximal inhibitory concentration: 3.9 ug/mL
Compound 3: middle estimate off by 1.2-fold (0.06 log units), on the high side, within the range that was stated.
By their numbers in this assay, from the lowest: compounds 1, 3 and 2 (each within the scatter of the next).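

In this assay, for the compounds shown here, the loss of the methyl group is now read directly for the first time, where the earlier step had only moved it. Exchanging the 2-methylphenyl for phenyl gives (a 1.5-fold lower number from compound 2 to compound 3 (0.18 log units; within the scatter)), and the same exchange of methyl for hydrogen starting from the other methylated compound gives (a 1.1-fold higher number from compound 1 to compound 3 (0.03 log units; within the scatter)). Neither the presence of the methyl on this aromatic ring nor its place therefore separates the three compounds beyond the scatter, and nothing at hand offers an explanation for this.

The compounds shown leave open whether a different group at this place, such as methoxy, a chlorine atom or an amine, would shift the number beyond the scatter. They also leave open what changes elsewhere on the shared core would do, since all three compounds carry it unaltered.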